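The compounds below may be only part of what the source reports. "The series", "measured", "known", "first", "only" and "open" are said of these compounds alone.

Readings in an ADME assay on MT4 cells (Homo sapiens) for cytotoxicity, read by MTT assay, with a stated time of 5 days (on this read-out higher numbers stand for lower toxicity in this test and lower numbers for higher toxicity in this test), so far:
- compound 1 `Cc1cc(C)cc(S(=O)(=O)c2c(C(=O)N[C@@H]3CCN(Cc4cccnc4)C3)[nH]c3ccc(Cl)cc23)c1` gives 36500 nM
- compound 2 `Cc1cc(C)cc(S(=O)(=O)c2c(C(=O)N[C@H]3CCN(S(C)(=O)=O)C3)[nH]c3ccc(Cl)cc23)c1` gives 29900 nM
- compound 3 `Cc1cc(C)cc(S(=O)(=O)c2c(C(=O)NC3CN(Cc4ccccc4C#N)C3)[nH]c3ccc(Cl)cc23)c1` gives > 234000 nM (a limit of the assay, not a number)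

Compound 3 stands at a limit and has no number of its own: the limit of > 234000 nM in this assay, at which 1 of the 3 values shown sits, is all that can be read for it.

Next to read is compound 4 `Cc1cc(C)cc(S(=O)(=O)c2c(C(=O)NC3CN(Cc4n[nH]c(=O)n4C)C3)[nH]c3ccc(Cl)cc23)c1`. The change from compound 3 is a group of 7 heavy atoms (3 carbon, 3 nitrogen, 1 oxygen; one five-membered aromatic ring with 3 hetero atoms) in place of a group of 8 heavy atoms (7 carbon, 1 nitrogen; one six-membered aromatic ring of carbon only), on a saturated chain carbon bound to an amine nitrogen in a ring, so the 2-cyanophenyl leaves and a group with no common name enters.

Among the compounds with values here, only one measured step bears on this, and only loosely, since it exchanges other groups: a 1.2-fold lower number from compound 1 to compound 2 (0.09 log units; within the scatter). That step gives no reason to expect a large move. Still, compound 1 at 36500 nM shows that numbers do occur in this series, so a reading for compound 4 cannot be ruled out.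

No step beyond the scatter is expected in this assay, and the estimated step is an at least 1.5-fold lower number from compound 3 to compound 4 (0.19 log units; that floor lies within the scatter). Compound 4 is estimated at 150000 nM, with an expected range of 40000 nM to 240000 nM.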

Compound 4, half-maximal cytotoxic concentration: 25200 nM
Compound 4: middle estimate off by 6.0-fold (0.77 log units), on the high side; the measured number lies below the stated range.
By their numbers in this assay, from the lowest: compounds 4, 2 and 1 (each within the scatter of the next). At a limit, above all of these: compound 3.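

In this assay, this position on the saturated chain carbon bound to an amine nitrogen in a ring proves sensitive to the group it carries: putting the group with no common name in place of 2-cyanophenyl gives an at least 9.2-fold lower number from compound 3 to compound 4 (0.96 log units; beyond the scatter), and this is the first step shown to lie beyond the scatter. Compound 3 remains a limit, not a number: the limit of > 234000 nM in this assay, at which 1 of the 4 values shown sits.

The other two steps, a 1.2-fold lower number from compound 2 to compound 4 (0.07 log units; within the scatter) and a 1.4-fold lower number from compound 1 to compound 4 (0.16 log units; within the scatter), lie within the scatter, so among these compounds only compound 3 stands apart.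

From the compounds shown here alone, the full size of the step stays open, as does whether the nitrile or the carbon-only aromatic ring of 2-cyanophenyl accounts for it. An unsubstituted phenyl at this place would separate those two readings.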